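A few compounds are considered here, and "the series" means these few. Any claim that something is new, unique, unknown or untested is made for them only; others in the source may bear on it.

Measured compounds:
- compound 1 `O=S(=O)(NCCCCCCNCc1ccc(Br)cc1)c1cc(Cl)cc(Cl)c1` — 12000 nM
- compound 2 `CC(C)c1ccc(S(=O)(=O)NCCCCCCNCc2ccc(Br)cc2)cc1` — 5730 nM
- compound 3 `O=[N+]([O-])c1ccccc1S(=O)(=O)NCCCCCCNCc1ccc(Br)cc1` — 11700 nM

Three sulfonamides built on the same core have been measured in a functional assay on MIA PaCa-2 cells (Homo sapiens) for inhibition, read by MTT assay, with a stated time of 72 h; on this read-out higher numbers stand for weaker inhibition of growth and lower numbers for stronger inhibition of growth. Compound 1, carrying 3,5-dichlorophenyl on the sulfonyl sulfur, gives 12000 nM; compound 2, with 4-isopropylphenyl there, gives 5730 nM; compound 3, with 2-nitrophenyl, gives 11700 nM. Compound 3 has the second highest of the three numbers. Its nearest neighbour is compound 1: a 1.0-fold lower number from compound 1 to compound 3 (0.01 log units; within the scatter), so the two are indistinguishable here. The only separation beyond the scatter is a 2.0-fold higher number from compound 2 to compound 3 (0.31 log units; beyond the scatter), matched by a 2.1-fold lower number from compound 1 to compound 2 (0.32 log units; beyond the scatter).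

Compound 4 `O=S(=O)(NCCCCCCNCc1ccc(Br)cc1)c1ccc(Cl)cc1` is not yet measured. It differs from compound 3 by 4-chlorophenyl in place of 2-nitrophenyl on a sulfonyl sulfur. Among the compounds with values here, the steps that bear on this are the two exchanges of the aryl group on the sulfonyl sulfur already seen: replacing 3,5-dichlorophenyl with 2-nitrophenyl changed nothing beyond the scatter, while the isopropyl-bearing aryl sat modestly lower. Since compound 4 carries a halogenated aryl, as compound 1 does, the step is expected to be small. Compound 4 is therefore estimated at 9000 nM, between 3500 nM and 23000 nM, implying an expected step of a 1.3-fold lower number from compound 3 to compound 4 (0.11 log units; within the scatter).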

Compound 4, concentration for 50% growth inhibition: 5900 nM
Estimate against measurement, compound 4: 1.5-fold (0.18 log units) above; the range from low to high includes it.
By their numbers in this assay, from the lowest: compounds 2, 4, 3 and 1 (each within the scatter of the next, the first and the last beyond it).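

In this assay the new result shows that a halogen on the aryl group does not by itself place a compound with compound 1: the step of a 2.0-fold lower number from compound 1 to compound 4 (0.31 log units; beyond the scatter) separates two chlorine-bearing aryl groups on a sulfonyl sulfur whose other neighbour is the sulfonamide nitrogen, although the step is modest. Chloro in place of isopropyl on an aromatic carbon gives a 1.0-fold higher number from compound 2 to compound 4 (0.01 log units; within the scatter) and so leaves compound 2 and compound 4 inseparable, which shows that 4-chlorophenyl and 4-isopropylphenyl cannot be told apart at this position. The exchange of 2-nitrophenyl for 4-chlorophenyl gives a 2.0-fold lower number from compound 3 to compound 4 (0.30 log units; within the scatter) and cannot be resolved either, so compound 3 overlaps both compound 1 and compound 4, and the aryl groups do not fall into two clean sets.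

Nothing shown accounts for the difference between compound 1 and compound 4. Still open, going by these compounds, is whether an aryl group carrying an amine or a carboxylic acid on the sulfonyl sulfur, or a longer chain in the shared core, would move the number by more than these modest steps.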